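The compounds below may be only part of what the source reports. "The series", "measured", "known", "first", "only" and "open" are said of these compounds alone.

Working notes on the series in a functional assay on PC-3 cells (Homo sapiens) for cytotoxicity; a lower number here means a stronger inhibitor, a higher number a weaker inhibitor.

Of the compounds shown here, two of the shared core have been measured. Compound 1 `COc1ccc2c(c1)c(/C=N\NC(=O)c1c[nH]c3ccc(Br)cc13)cn2Cc1ccc(Cl)cc1` gives 15900 nM. Compound 2 `O=C(N/N=C\c1cn(Cc2ccc(Cl)cc2)c2cc(F)ccc12)c1c[nH]c2ccccc12` gives 19500 nM. The two numbers lie within the scatter of each other, so nothing separates compound 1 from compound 2 on these figures; both sit in the same region, and no ordering between them can be read from the data. Among the compounds with values here, no pair of measured compounds differs in a single place, so no measured step is available to anchor the next change.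

Compound 3 `COc1ccc2c(c1)c(/C=N\NC(=O)c1cn(C)c3ccccc13)cn2Cc1ccc(Cl)cc1` is not yet measured. It differs from compound 1 in one place: 1-methyl-1H-indol-3-yl in place of 5-bromo-1H-indol-3-yl on a carbonyl carbon. Within the data shown here, nothing measured bears on this exchange, since no other pair in the set varies the indolyl group on the carbonyl carbon. Among the measured compounds shown here, with both measured compounds close together and no step to guide the direction, the expectation for compound 3 is a step of a 1.3-fold higher number from compound 1 to compound 3 (0.10 log units; within the scatter) that stays within the scatter, with no particular direction. The value for compound 3 is therefore estimated at 20000 nM, within a range of 8000 nM to 50000 nM, the range kept wide for an untested change.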

Compound 3, half-maximal inhibitory concentration: 21200 nM
Estimate against measurement, compound 3: 1.1-fold (0.03 log units) below; the measured number falls inside the stated range.
By their numbers in this assay, from the lowest: compounds 1, 2 and 3 (each within the scatter of the next).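

In this assay, within the data shown here, this is the first exchange that can be read in one place: on a carbonyl carbon whose other neighbour is an amide-type nitrogen, 1-methyl-1H-indol-3-yl in place of 5-bromo-1H-indol-3-yl gives a 1.3-fold higher number from compound 1 to compound 3 (0.12 log units; within the scatter), so this change does not separate the two compounds. The exchange removes the bromine and also the hydrogen-bond donor of the leaving group, and neither alteration, taken together with the other, comes with a step that the scatter can distinguish; the two alterations cannot be told apart here, since they arrive in a single step. Nothing available explains this result or bears on how the two groups compare in this assay.

Still open, from the compounds shown here alone, is whether a more different group on this carbonyl carbon, such as an indol-3-yl carrying a carboxylic acid or an amine, or a longer chain in place of the methyl on the indole, would give a step beyond the scatter. Among these compounds, the other places on the shared core have no single-place step yet, so their contribution to the numbers remains unread.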